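A few compounds are considered here, and "the series" means these few. Any claim that something is new, unique, unknown or untested is made for them only; others in the source may bear on it.

Measured compounds and their values in a functional assay on the whole organism (stomach) for inhibition, with Canis familiaris (Canis lupus familiaris) as the target, at a dose of 5 mg/kg by the intravenous route; a lower number here means a weaker effect, a higher number a stronger effect of the compound at the dose given:

compound 1, `CC(=O)c1c(C)nc2c(OCc3ccccc3)cccn12`, gives 9%
compound 2, `Cc1nc2c(OCc3ccccc3)cccn2c1CCC#N`, gives 20%
compound 3, `CSCc1c(C)nc2c(OCc3ccccc3)cccn12`, gives 8%

Compound 2 stands highest of the three: the step of a number 11 percentage points higher from compound 1 to compound 2 (beyond the scatter) and the step of a number 12 percentage points lower from compound 2 to compound 3 (beyond the scatter) are both beyond the scatter, while compound 1 and compound 3 sit within the scatter of each other, as the step of a number 1 percentage points lower from compound 1 to compound 3 (within the scatter) shows.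

Compound 4, `CCCCC(=O)OCc1c(C)nc2c(OCc3ccccc3)cccn12`, is not yet measured. It differs from compound 2 at the saturated chain carbon bound to an aromatic carbon: (butylcarbonyl)oxy in place of cyanomethyl on a saturated chain carbon bound to an aromatic carbon

Among the measured compounds shown here, two measured steps bear on this change. Both put something other than the cyanomethyl-bearing chain at this place and both end at the lower level: compound 1 and compound 3 sit there, and the step of a number 12 percentage points lower from compound 2 to compound 3 (beyond the scatter), which removes cyanomethyl from the same chain carbon, is a modest loss. A step of similar size and direction is therefore expected, a number 10 percentage points lower from compound 2 to compound 4 (within the scatter), because the step of a number 12 percentage points lower from compound 2 to compound 3 (beyond the scatter) went the same way. Compound 4 is thus estimated at 10%, expected between 2% and 22%.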

Compound 4, a percentage reported as inhibition, in the whole organism at one dose (the size of the read-out at that dose, not a potency): 96%
Compound 4: middle estimate off by 86 percentage points, on the low side, and the stated range ends below it.
By their numbers in this assay, from the lowest: compounds 3 and 1 (each within the scatter of the next); then compound 2; then compound 4.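

In this assay, among the compounds shown here, the group at this place can matter far more than the earlier compounds suggested. For the compounds shown here, the ((butylcarbonyl)oxy)methyl group of compound 4 stands well clear of the acetyl group (a number 87 percentage points higher from compound 1 to compound 4 (beyond the scatter)), and (butylcarbonyl)oxy on the saturated chain carbon also gives large steps against cyanomethyl (a number 76 percentage points higher from compound 2 to compound 4 (beyond the scatter)) and against methylsulfanyl (a number 88 percentage points higher from compound 3 to compound 4 (beyond the scatter)), whereas the earlier steps were modest or within the scatter. No measurement shown here accounts for this large rise.

The compounds shown leave open whether the rise depends on the butyl part of the chain or on the oxygen that links it to the chain carbon. A shorter acetyloxy group, a longer acyl chain, a free hydroxyl or an amide at the same place would help separate these possibilities.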